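A few compounds are considered here, and "the series" means these few. Any claim that something is new, unique, unknown or untested is made for them only; others in the source may bear on it.

Compound 1 `COc1ccccc1/C=c1/[nH]c(=O)/c(=C\c2ccccc2OC)[nH]c1=O` was tested in a functional assay on A549 cells (Homo sapiens) for cytotoxicity, read by CCK-8 assay, with a stated time of 72 h (on this read-out lower numbers stand for stronger inhibition and higher numbers for weaker inhibition), where compound 1 gives "not active" (no number reported), so no single number marks where it stands. Two related compounds carry numbers: compound 2 `C=CCn1c(=O)/c(=C\c2ccccc2OC)[nH]c(=O)/c1=C\c1ccccc1OC` gives 22400 nM, and compound 3 `COc1ccccc1/C=c1/[nH]c(=O)/c(=C\c2ccccc2OC)n(C)c1=O` gives 7000 nM; the step of a 3.2-fold lower number from compound 2 to compound 3 (0.51 log units; beyond the scatter) concerns a change on an aromatic nitrogen. Compound 4 `COc1ccccc1/C=c1/[nH]c(=O)/c(=C\c2nc[nH]c2C(C)(C)C)[nH]c1=O` differs from compound 1 at a different site: 5-(tert-butyl)-1H-imidazol-4-yl in place of 2-methoxyphenyl on a double-bonded chain carbon bound to an aromatic carbon. Going by the values given here, no measured step bears on this exchange, and compound 1 itself offers no number to step from, so no direction beyond the scatter can be expected with confidence. On this weak footing compound 4 is expected to give 30000 nM, in a range from 7000 nM to 120000 nM.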

Compound 4, half-maximal inhibitory concentration: 90 nM
Compound 4: middle estimate off by 330-fold (2.52 log units), on the high side; the whole stated range lies above it.
By their numbers in this assay, from the lowest: compound 4; then compound 3; then compound 2.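

Going by these compounds alone, no step from compound 1 to compound 4 can be read, as compound 1 gives "not active" (no number reported). The compounds shown leave open what the 5-(tert-butyl)-1H-imidazol-4-yl group contributes to the value of compound 4, and no evidence on this is available.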